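The source may hold more compounds than are shown below. What is called first, only, known or untested is meant among the compounds shown, and "the series" means these compounds.

Measured in a functional assay on HepG2 cells (Homo sapiens) for antiproliferative activity, read by MTT assay, with a stated time of 48 h; a lower number here means a stronger inhibitor, a higher number a weaker inhibitor:

Compound 1 `CCN(CC)CCNC(=O)c1ccc(C(CC)(CC)c2ccc(OCCC(O)(CC)CC)c(C)c2)n1CC`: 230 nM
Compound 2 `CCC(C)C(CO)NC(=O)c1ccc(C(CC)(CC)c2ccc(OCCC(O)(CC)CC)c(C)c2)n1CC`: > 50000 nM

Compound 2 stands at > 50000 nM, which is a limit of the assay and not a number.

Compound 3 `CCn1c(C(=O)N(C)CCO)ccc1C(CC)(CC)c1ccc(OCCC(O)(CC)CC)c(C)c1` has not yet been measured. It keeps the core of compound 2 and differs on a carbonyl carbon, where (2-hydroxyethyl)(methyl)amino stands in place of (1-(hydroxymethyl)-2-methylbutyl)amino ((2-hydroxyethyl)(methyl)amino in place of (1-(hydroxymethyl)-2-methylbutyl)amino on a carbonyl carbon).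

For the measured compounds named here, the one measured step that bears on this change is an at least 210-fold higher number from compound 1 to compound 2 (2.33 log units; beyond the scatter), which is large and beyond the scatter. It involves the same place, but it removes the 2-(diethylamino)ethyl group of compound 1, and compound 3 does not regain that group. The incoming and the leaving group both carry no net charge. Compound 3 is therefore expected to stay near compound 2 in this assay, with no large step in either direction, and it may well report only a limit too.

For compound 3 the estimated value is 40000 nM, with an expected range from 10000 nM to 100000 nM.

This estimate means an expected at least 1.2-fold lower number from compound 2 to compound 3 (0.09 log units; that floor lies within the scatter).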

Compound 3, half-maximal inhibitory concentration: 510 nM
Compound 3: middle estimate off by 78-fold (1.89 log units), on the high side; measured number outside the range, below it.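

In this assay the result shows that this place on the carbonyl carbon does not depend on the 2-(diethylamino)ethyl group, since (2-hydroxyethyl)(methyl)amino in place of (1-(hydroxymethyl)-2-methylbutyl)amino gives an at least 98-fold lower number from compound 2 to compound 3 (1.99 log units; beyond the scatter) and so restores a strong inhibitor. Set against the amine-bearing side chain, the same group gives only a 2.2-fold higher number from compound 1 to compound 3 (0.35 log units; beyond the scatter), a modest step, so two groups with no net charge, (1-(hydroxymethyl)-2-methylbutyl)amino and (2-hydroxyethyl)(methyl)amino, can end far apart here while the second stays close to (2-(diethylamino)ethyl)amino. The step from compound 2 has only a floor, as the value of compound 2 is a limit of the assay and not a number: the limit of > 50000 nM in this assay, at which 1 of the 3 values shown sits.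

The change replaces the branched chain and adds the methyl of (2-hydroxyethyl)(methyl)amino at once, so the compounds shown cannot tell which of the two carries the large step. They also leave open how a plain 2-hydroxyethylamino group, without that methyl, or a cyclic amine such as morpholine would stand at this place in this assay.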